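Replacing the hydroxylated side chain with an acetoxypentyl ester

The source may hold more compounds than are shown below. What is called first, only, known or untested is meant among the compounds shown, and "the series" means these compounds.

Compound 1 `CCC(C)(O)CC(=O)O[C@H](CC=C(C)C)C1=CC(=O)c2c(O)ccc(O)c2C1=O`: 25200 nM
Compound 2 `CC(C)=CC[C@@H](OC(=O)CC(C)(O)c1ccccc1)C1=CC(=O)c2c(O)ccc(O)c2C1=O`: 85700 nM
Compound 3 `CC[C@](C)(O)CC(=O)O[C@H](CC=C(C)C)C1=CC(=O)c2c(O)ccc(O)c2C1=O`: 30200 nM

In a functional assay on HeLa cells (Homo sapiens) for cytotoxicity, read by MTT assay (on this read-out higher numbers stand for weaker inhibition and lower numbers for stronger inhibition), compound 3 stands second highest of the three numbers; its gap to compound 1 is within the scatter, while compound 2 sits further off, as seen in a 2.8-fold lower number from compound 2 to compound 3 (0.45 log units; beyond the scatter). Compound 4 `CCCCC(CC(=O)O[C@H](CC=C(C)C)C1=CC(=O)c2c(O)ccc(O)c2C1=O)OC(C)=O` is not yet measured. Compared with compound 3, (1-acetoxypentyl in place of 1-hydroxy-1-methylpropyl on a saturated chain carbon bound to a carbonyl carbon). For the measured compounds named here, the one measured change at this saturated chain carbon bound to a carbonyl carbon, a 3.4-fold higher number from compound 1 to compound 2 (0.53 log units; beyond the scatter), was modest, so a similarly modest step is expected here, with the direction uncertain and a lean toward a somewhat higher number because of a 3.4-fold higher number from compound 1 to compound 2 (0.53 log units; beyond the scatter). Compound 4 is therefore estimated at 45000 nM, between 15000 nM and 130000 nM, meaning a 1.5-fold higher number from compound 3 to compound 4 (0.17 log units; within the scatter).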

Compound 4, half-maximal inhibitory concentration: 73500 nM
Compound 4: middle estimate off by 1.6-fold (0.21 log units), on the low side; low and high end bracket the measured number.
By their numbers in this assay, from the lowest: compounds 1 and 3 (each within the scatter of the next); then compounds 4 and 2 (each within the scatter of the next).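

In this assay, the 1-acetoxypentyl group gives a 2.4-fold higher number from compound 3 to compound 4 (0.39 log units; beyond the scatter) and a 2.9-fold higher number from compound 1 to compound 4 (0.46 log units; beyond the scatter). For the compounds shown here, a phenyl group is therefore not the only change at this saturated chain carbon bound to a carbonyl carbon that raises the number, and a 1.2-fold lower number from compound 2 to compound 4 (0.07 log units; within the scatter) puts the two larger groups level. Nothing in the data given explains these steps.

Compound 4 swaps the hydroxyl for an acetoxy group and lengthens the chain in one move, so the compounds shown leave open which of the two changes counts. A 1-hydroxypentyl group in the same place would separate them.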